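Moving the Bromine to Another Place on the Phenyl Ring

The source may hold more compounds than are shown below. What is called first, only, known or untested is meant among the compounds shown, and "the series" means these compounds.

Compound 3 `Cc1ccc(CS(=O)(=O)/C(=C/c2ccc(Br)cc2)C(=O)c2ccc(Cl)cc2)cc1` was tested in a functional assay on DU-145 cells (Homo sapiens) for inhibition, read by trypan blue exclusion, with a stated time of 96 h (a lower number here means a stronger inhibitor of growth, a higher number a weaker inhibitor of growth), where compound 3 gives 25000 nM. Two related compounds frame that number: compound 1 `Cc1ccc(CS(=O)(=O)/C(=C/c2c[nH]c3ccccc23)C(=O)c2ccc(Cl)cc2)cc1` gives 25000 nM, and compound 2 `Cc1ccc(CS(=O)(=O)/C(=C/c2c[nH]c3ccc(Br)cc23)C(=O)c2ccc(Cl)cc2)cc1` gives 10000 nM. Among the compounds with values here, compound 3 stands level with compound 1, the two together holding the highest numbers of the three, and its only step beyond the scatter is a 2.5-fold higher number from compound 2 to compound 3 (0.40 log units; beyond the scatter). The other steps are a 2.5-fold lower number from compound 1 to compound 2 (0.40 log units; beyond the scatter), where a bromo was added to the 1H-indol-3-yl compound, and no change at the digits printed from compound 1 to compound 3 (within the scatter), where the whole group on the chain carbon was exchanged.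

Compound 4 `Cc1ccc(CS(=O)(=O)/C(=C/c2ccccc2Br)C(=O)c2ccc(Cl)cc2)cc1` differs from compound 3 in one place: 2-bromophenyl in place of 4-bromophenyl on a double-bonded chain carbon bound to a double-bonded chain carbon. Within the data shown here, no measured step moves a bromine from one position to another on the same ring; the steps at hand concern adding a bromo or exchanging the group, and each was at most modest. Among the measured compounds shown here, with no direct precedent, the expected step of no change at the digits printed from compound 3 to compound 4 (within the scatter) is none beyond the scatter. Compound 4 is therefore estimated at 25000 nM, in a range from 10000 nM to 60000 nM.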

Compound 4, concentration for 50% growth inhibition: 25000 nM
Estimate against measurement, compound 4: no gap at the digits printed; measured number inside the range.
By their numbers in this assay, from the lowest: compound 2; then compounds 1, 3 and 4 (each within the scatter of the next).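

Moving the bromine from the 4-bromophenyl to the 2-bromophenyl arrangement gives no change at the digits printed from compound 3 to compound 4 (within the scatter) in this assay, the first direct reading of bromine position on this ring, and the two placements cannot be told apart here. Against the indoles, the 2-bromophenyl group behaves as the 4-bromophenyl group did: replacing 1H-indol-3-yl gives no change at the digits printed from compound 1 to compound 4 (within the scatter), while replacing 5-bromo-1H-indol-3-yl gives a 2.5-fold higher number from compound 2 to compound 4 (0.40 log units; beyond the scatter) in the same assay. No measurement shown explains why the place of the bromine leaves the number unmoved.

Whether the bromine contributes at all remains open, as a plain phenyl group does not appear among these compounds. Also open, from the compounds shown here alone, is whether an amine or a carboxylic acid in place of the bromine would shift the growth inhibition.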